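Methylsulfanyl in Place of Chloro on a Thromboxane Synthase Core

A few compounds are considered here, and "the series" means these few. Any claim that something is new, unique, unknown or untested is made for them only; others in the source may bear on it.

Measured so far:
compound 1 `O=C(O)c1ccc2sc(Cn3ccnc3)c(Cl)c2c1`: 22 nM
compound 2 `Cc1c(Cn2ccnc2)[nH]c2ccc(C(=O)O)cc12`: 37 nM

In an assay for inhibition of Thromboxane-A synthase (Homo sapiens) (on this read-out lower numbers stand for stronger inhibition and higher numbers for weaker inhibition), compound 1 gives 22 nM and compound 2 gives 37 nM. The two numbers lie within the usual scatter of each other, so neither compound can be set apart on this assay. Compound 3 `CSc1c(Cn2ccnc2)sc2ccc(C(=O)O)cc12` differs from compound 1 in one place: methylsulfanyl in place of chloro on an aromatic carbon. Within the data shown here, no step between two measured compounds shows what this swap does, so the expected change is none beyond the scatter, with a wide range to allow for surprise. The expected step is a 1.4-fold higher number from compound 1 to compound 3 (0.13 log units; within the scatter). Compound 3 is therefore estimated at 30 nM, with a range from 10 nM to 90 nM.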

Compound 3, half-maximal inhibitory concentration: 43 nM
For compound 3 the middle estimate is 1.4-fold (0.16 log units) below the measured one; measured number inside the range.
By their numbers in this assay, from the lowest: compounds 1, 2 and 3 (each within the scatter of the next).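

In this assay, putting methylsulfanyl in place of chloro on this aromatic carbon gives a 2.0-fold higher number from compound 1 to compound 3 (0.29 log units; within the scatter) and so makes no difference that can be told from the usual scatter. Among these compounds, this is the first direct reading at this position, and it shows that the core of compound 1 can carry either group here with its inhibition still in the same range. No measured evidence is available to explain this result.

As far as these compounds go, it remains open whether an amine, a carboxylic acid or a longer chain such as butylsulfanyl would be accommodated as readily at this position.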